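The compounds below may be only part of what the source reports. "The series", "measured", "known", "first", "only" and "open" are said of these compounds alone.

Notes on a set of diaryl ureas examined in an ADME assay on Raji cells (Homo sapiens) for cytotoxicity, with a stated time of 72 h; a lower number here means that less compound is needed, a higher number that more compound is needed for the effect. Compound 1 `Cc1cc(NC(=O)Nc2ccccc2OC(F)(F)F)c2ccccc2n1` carries a trifluoromethoxy group, and in this assay compound 1 gives only a limit, > 25000 nM. Compound 2 `COc1ccccc1NC(=O)Nc1cc(C)nc2ccccc12` is the methoxy counterpart, and in this assay compound 2 likewise gives only a limit, > 25000 nM. The change from compound 2 to compound 1 is trifluoromethyl in place of methyl on an oxygen on an aromatic ring; the step it made is a step that the two limits leave unreadable from compound 2 to compound 1. Compound 3 `COc1cccc(NC(=O)Nc2cc(C)nc3ccccc23)c1` has the same atoms as compound 2 joined differently; how the two cores differ is not broken down here. In this assay compound 3 also gives only a limit, > 25000 nM. Going by the values given here, every value so far sits at the limit of > 25000 nM in this assay, at which 3 of the 3 values shown sit, so no step in the set can be read. Compound 4 `Cc1cc(NC(=O)Nc2cccc(OC(F)(F)F)c2)c2ccccc2n1` remains to be measured. It stands to compound 3 as compound 1 stands to compound 2: trifluoromethyl in place of methyl on an oxygen on an aromatic ring, the same change at the same place. The step expected here is a step that the limit leaves unreadable from compound 3 to compound 4, an expectation resting only on a step that the two limits leave unreadable from compound 2 to compound 1 and the three limits. Compound 4 is therefore estimated at 30000 nM, most probably reported again as a limit rather than a number.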

Compound 4, half-maximal effective concentration: 9000 nM
The estimate for compound 4 lay 3.3-fold (0.52 log units) above the measured number; the measured number lies below the stated range.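

In this assay, going by these compounds alone, the change from methoxy to trifluoromethoxy gives an at least 2.7-fold lower number from compound 3 to compound 4 (0.44 log units; beyond the scatter), a step beyond the scatter, but this is the only pair in the set where the change can be read. The same change in the other core, from compound 2 to compound 1, cannot be read, and compound 4 is the only one of the two trifluoromethoxy compounds to give a number, while compound 1 gives only a limit, so the step is not shown to carry from one core to the other, nor is it shown to fail. The true size of the step in either core also stays unknown, and the set gives little to compare: the limit of > 25000 nM in this assay, at which 3 of the 4 values shown sit.

On these data alone, it remains open whether a number would also appear with other groups on the same oxygen, such as difluoromethyl or a longer chain. As far as these compounds go, it also remains open how an amine or a carboxylic acid in place of the whole trifluoromethoxy group would read in either core.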